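Substituting the Amino Nitrogen of Compound 3

This account rests on a few compounds, and the source may have more. Where it says the series, first, only, none or still open, it means among the compounds named here.

Compound 1 `COc1cc(OC)c(/C=C/S(=O)(=O)Nc2cc(N)c(OC)c(N)c2)c(OC)c1`: 2500 nM
Compound 2 `COc1ccc(NS(=O)(=O)/C=C/c2c(OC)cc(OC)cc2OC)cc1`: 200 nM
Compound 3 `COc1cc(OC)c(/C=C/S(=O)(=O)Nc2ccc(OC)c(N)c2)c(OC)c1`: 5 nM

All three numbers come from a functional assay on DU-145 cells (Homo sapiens) for cytotoxicity, read by trypan blue exclusion, with a stated time of 96 h; on this read-out higher numbers stand for weaker inhibition and lower numbers for stronger inhibition. Compound 3 has the lowest number of the set at 5 nM, which makes it the strongest inhibitor of the three.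

Compound 4 `COC(=O)C(Nc1cc(NS(=O)(=O)/C=C/c2c(OC)cc(OC)cc2OC)ccc1OC)c1ccc(F)cc1` has not been measured yet. It differs from compound 3 in one place: (4-fluorophenyl)(methoxycarbonyl)methyl in place of hydrogen on a nitrogen on an aromatic ring. In words, (4-fluorophenyl)(methoxycarbonyl)methyl stands in place of hydrogen on a nitrogen on an aromatic ring.

Among the measured compounds shown here, two measured steps bear on this change, and both are large. Amino in place of hydrogen on an aromatic carbon gave a 40-fold lower number from compound 2 to compound 3 (1.60 log units; beyond the scatter), and that amino nitrogen is the one that changes in compound 4. Hydrogen in place of amino on an aromatic carbon gave a 500-fold lower number from compound 1 to compound 3 (2.70 log units; beyond the scatter). So amino groups on this ring have gone with big shifts in this assay, but no measured compound carries a substituent on such a nitrogen.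

With compound 3 at the low end, a move to a higher number, meaning weaker inhibition, seems most likely, perhaps back towards compound 2 at 200 nM. The expected change is a 20-fold higher number from compound 3 to compound 4 (1.30 log units; beyond the scatter). The estimate for compound 4 is 100 nM, with an expected range from 15 nM to 1500 nM.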

Compound 4, half-maximal inhibitory concentration: 2500 nM
For compound 4 the middle estimate is 25-fold (1.40 log units) below the measured one; measured number above the stated range.
By their numbers in this assay, from the lowest: compound 3; then compound 2; then compounds 1 and 4 (each within the scatter of the next).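

In this assay, putting (4-fluorophenyl)(methoxycarbonyl)methyl in place of hydrogen on the nitrogen on the aromatic ring gives a 500-fold higher number from compound 3 to compound 4 (2.70 log units; beyond the scatter), a step well beyond the scatter. Among the compounds shown here, the earlier compounds showed only what happens when an amino group is added to or removed from a ring carbon; this result is the first to show that changing the amino nitrogen itself can also cost a great deal of inhibition, so the low number of compound 3 does not survive this substitution. Nothing measured here explains why this group, with its 12 heavy atoms, has such a large effect.

Because this is the only substituent shown on that nitrogen, it remains open whether the loss belongs to substitution as such or to this particular group, and a single methyl group or a short acetyl group could tell those two readings apart. From the compounds shown here alone, it is equally open which part of the group matters, and versions with a carboxylic acid in place of the methyl ester, or a plain phenyl ring in place of the 4-fluorophenyl ring, would separate those parts.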